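Purine-like nucleosides: thiophene versus phenyl at the five-ring

This account rests on a few compounds, and the source may have more. Where it says the series, first, only, none or still open, it means among the compounds named here.

Three compounds are measured in a functional assay on HepG2 cells (Homo sapiens) for antiproliferative activity, read by XTT assay, with a stated time of 72 h; on this read-out lower numbers stand for stronger inhibition and higher numbers for weaker inhibition. For the measured compounds named here, compound 2 `COc1ncnc2c1c(-c1cccs1)cn2[C@@H]1O[C@H](CO)[C@@H](O)[C@H]1O` gives 13900 nM, the only number in the set. Compound 3 `COc1nc(N)nc2c1c(-c1cccs1)cn2[C@@H]1O[C@H](CO)[C@@H](O)[C@H]1O` returns only a limit of the assay, > 20000 nM. Compound 1 `COc1nc(N)nc2c1c(-c1ccccc1)cn2[C@@H]1O[C@H](CO)[C@@H](O)[C@H]1O` likewise returns only a limit, > 20000 nM. Compound 4 `COc1ncnc2c1c(-c1ccccc1)cn2[C@@H]1O[C@H](CO)[C@@H](O)[C@H]1O` is not yet measured in this assay.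

The cores of compound 3 and compound 2 differ by hydrogen in place of amino on an aromatic carbon; that change gives an at least 1.4-fold higher number from compound 2 to compound 3 (0.15 log units; that floor lies within the scatter). From compound 3 to compound 1 the change is phenyl in place of thiophen-2-yl on an aromatic carbon, and its step is a step that the two limits leave unreadable from compound 3 to compound 1 because of the limit of > 20000 nM in this assay, at which 2 of the 3 values shown sit. The change from compound 2 to compound 4 is phenyl in place of thiophen-2-yl on an aromatic carbon, the same change at the same place.

Going by the values given here, as the only read of this change sits on two limits, it gives no direction, and compound 2 is the sole anchor. The expected step is a 1.3-fold higher number from compound 2 to compound 4 (0.11 log units; within the scatter), resting on compound 2 at 13900 nM and on the unreadable step from compound 3 to compound 1. Compound 4 is estimated at 18000 nM, with a range from 7000 nM to 45000 nM.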

Compound 4, half-maximal inhibitory concentration: > 20000 nM
Compound 4 ended at the assay's limit; the forecaster's own chance of this, stated with the estimate: 45%; middle value at least 1.1-fold (0.04 log units) away from the limit.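

In this assay, phenyl in place of thiophen-2-yl on the core of compound 2 gives an at least 1.4-fold higher number from compound 2 to compound 4 (0.15 log units; that floor lies within the scatter). The same change on the amino-bearing core, and the amino-to-hydrogen step between the two phenyl compounds, cannot be read, because both ends of each step are limits rather than numbers: the limit of > 20000 nM in this assay, at which 3 of the 4 values shown sit. The data therefore do not show that the change carries from one core to the other, and they give no direction or size for it on the amino-bearing core, while on the core of compound 2 they give only a floor within the scatter.

Still open, from the compounds shown here alone, is whether any group on this aromatic carbon gives a clear number rather than a limit, for example a carboxylic acid, a primary amine or a longer alkyl chain in place of thiophen-2-yl or phenyl. Also open, going by these compounds, is whether a read on the amino-bearing core could be had at all with such a group, since only then could the two cores be compared.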